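Replacing an Anilino Group with Diethylamino on a Fused Core

A few compounds are considered here, and "the series" means these few. Any claim that something is new, unique, unknown or untested is made for them only; others in the source may bear on it.

Measured compounds:
compound 1, `N#Cc1c(N)c(Cl)c2nc(N)nc(N)c2c1Cl`: 188 ug/mL
compound 2, `N#Cc1c(Nc2ccc(Cl)cc2)c(F)c2nc(N)nc(N)c2c1F`: 115 ug/mL

Both compounds were tested in a functional assay on A549 cells (Homo sapiens) for cytotoxicity, read by MTT assay; a higher number here means a weaker inhibitor, a lower number a stronger inhibitor. Within the data shown here, compound 2 stands alongside compound 1: the gap between the two values lies within the usual scatter of repeated measurements, so neither compound can be called the stronger or weaker inhibitor on these numbers alone, and no step between them is counted.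

Compound 3, `CCN(CC)c1c(C#N)c(F)c2c(N)nc(N)nc2c1F`, differs from compound 2 in one place: diethylamino in place of (4-chlorophenyl)amino on an aromatic carbon. Among the measured compounds shown here, no pair of measured compounds in this set shows what such a change does in this assay, so the expectation can rest only on the values of compound 2 and compound 1, which lie close together. In this assay compound 3 is expected to give about 150 ug/mL, with a range from 70 ug/mL to 320 ug/mL. That estimate means a step of a 1.3-fold higher number from compound 2 to compound 3 (0.12 log units; within the scatter), expected to be small, toward a somewhat higher number, and possibly not beyond the scatter at all.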

Compound 3, half-maximal inhibitory concentration: 26.5 ug/mL
Estimate against measurement, compound 3: 5.7-fold (0.75 log units) above; the measured number lies below the stated range.
By their numbers in this assay, from the lowest: compound 3; then compounds 2 and 1 (each within the scatter of the next).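

In this assay, putting diethylamino in place of (4-chlorophenyl)amino gives a 4.3-fold lower number from compound 2 to compound 3 (0.64 log units; beyond the scatter), a modest step beyond the scatter, so the group on this aromatic carbon, ortho to a cyano group and ortho to a fluoro group, can change the read-out. Among these compounds, the earlier compounds offered no step that differed in one place, and this is the first such change that can be read in the set. The change removes an aromatic ring and a hydrogen-bond donor in a single step, but no measurement bears on why the number falls.

With only this one pair, the compounds shown leave open whether the ring, the hydrogen-bond donor, the chlorine or the diethylamino group itself accounts for the step. Going by these compounds, a plain phenylamino group, a dimethylamino group or a piperidine at this carbon would begin to separate these parts, and it also remains open whether the same change would give a similar step on the core of compound 1, which carries chloro groups in place of the fluoro groups.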